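Amide nitrogen swap: 4-methylbenzyl for 3-methoxyphenyl

The source may report more compounds than this note shows. Statements on the series, on what has been measured and on what is new or still open speak of the compounds shown alone.

Measured so far:
compound 1 `COc1cccc(NC(=O)/C=C/c2coc3cc(OC)ccc3c2=O)c1`: 11100 nM
compound 2 `COc1ccc(NC(=O)/C=C/c2coc3cc(O)ccc3c2=O)cc1`: a limit only, > 100000 nM

Going by the values given here, compound 1 holds the only plain number in a functional assay on Huh-7 cells (Homo sapiens) for inhibition, read by MTT assay, with a stated time of 48 h; a higher number here means a weaker inhibitor, a lower number a stronger inhibitor; the other result is a limit of the assay. Compound 3 `COc1ccc2c(=O)c(/C=C/C(=O)NCc3ccc(C)cc3)coc2c1` is not yet measured in this assay. It differs from compound 1 by 4-methylbenzyl in place of 3-methoxyphenyl on an amide-type nitrogen. Among the compounds with values here, no measured pair covers this change, so the direction rests on the change alone; a modest step toward weaker inhibition is expected, a 1.8-fold higher number from compound 1 to compound 3 (0.26 log units; within the scatter), about at the edge of the scatter. Compound 3 is therefore estimated at 20000 nM, with a range from 5000 nM to 80000 nM.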

Compound 3, half-maximal inhibitory concentration: 14300 nM
Compound 3: the middle estimate sits 1.4-fold (0.15 log units) above what was measured; low and high end bracket the measured number.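

In this assay the swap on the amide-type nitrogen gives a 1.3-fold higher number from compound 1 to compound 3 (0.11 log units; within the scatter) and so does not separate the two groups. On this core, 4-methylbenzyl and 3-methoxyphenyl read alike at this position, although only 3-methoxyphenyl counts a hydrogen-bond acceptor. Nothing shown gives a cause for this step.

From the compounds shown here alone, whether any group on this nitrogen can move the reading beyond the scatter stays open, as these two groups alone share the core. An amine or a carboxylic acid on the aromatic ring, or a longer chain on the amide nitrogen, would test this.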